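Ethylsulfanyl in place of methylsulfanyl on the carbamate-like tail

The source may hold more compounds than are shown below. What is called first, only, known or untested is meant among the compounds shown, and "the series" means these compounds.

Of the compounds shown here, three sharing one core have been measured. Compound 1 `COC(=O)N1CCC(Oc2ncnc3c2CCN3c2ccc(S(C)(=O)=O)cc2F)CC1` gives 119% in a functional assay on CHO-K1 cells with Glucose-dependent insulinotropic receptor (Homo sapiens) as the target, read by a luciferase reporter, with a stated time of 5 h; on this read-out lower numbers stand for smaller maximal responses and higher numbers for larger maximal responses. Compound 2 `CC(C)(C)COC(=O)N1CCC(Oc2ncnc3c2CCN3c2ccc(S(C)(=O)=O)cc2F)CC1` gives 80% in the same assay, and compound 3 `CSC(=O)N1CCC(Oc2ncnc3c2CCN3c2ccc(S(C)(=O)=O)cc2F)CC1` gives 135%. Compound 3 stands highest of the three; the step of a number 16 percentage points higher from compound 1 to compound 3 (beyond the scatter) is modest, while the step of a number 55 percentage points higher from compound 2 to compound 3 (beyond the scatter) is large. The step of a number 39 percentage points lower from compound 1 to compound 2 (beyond the scatter) shows that lengthening the chain on the oxygen side of the carbonyl lowered the response strongly.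

Compound 4 `CCSC(=O)N1CCC(Oc2ncnc3c2CCN3c2ccc(S(C)(=O)=O)cc2F)CC1` differs from compound 3 by methyl in place of hydrogen on a saturated chain carbon bound to a sulfur. Among the compounds with values here, the only measured step that bears on a longer chain at this tail is a number 39 percentage points lower from compound 1 to compound 2 (beyond the scatter), a large drop for a much bulkier group than the one entering here; no measured step adds a single methyl on the sulfur side. A step smaller than that one, and possibly within the scatter, is therefore expected: a number 15 percentage points lower from compound 3 to compound 4 (beyond the scatter). For compound 4 the estimate in this assay is 120%, with a range from 95% to 140%.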

Compound 4, largest response reached (reported as percent of maximum), in percent of the reference or control that the assay uses: 128%
Beside the measured number, compound 4's estimate is 8 percentage points below it; the range from low to high includes it.
By their numbers in this assay, from the lowest: compound 2; then compounds 1, 4 and 3 (each within the scatter of the next, the first and the last beyond it).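

The methyl added on the saturated chain carbon bound to a sulfur is the first change shown on the sulfur side of this tail, and in this assay the ethylsulfanyl compound cannot be told apart from the methylsulfanyl one (a number 7 percentage points lower from compound 3 to compound 4 (within the scatter)). Ethylsulfanyl also cannot be told apart from methoxy on the carbonyl carbon (a number 9 percentage points higher from compound 1 to compound 4 (within the scatter)), while it stands clearly apart from neopentyloxy (a number 48 percentage points higher from compound 2 to compound 4 (beyond the scatter)), so the large loss seen with neopentyloxy does not appear with this one added methyl. Nothing available here accounts for these steps.

On these data alone, it stays open whether a longer chain on the sulfur, such as propyl or tert-butyl, would hold the response in this assay or approach compound 2 at 80%. An ethoxy group on the carbonyl carbon would also be needed to compare oxygen and sulfur at the same chain.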